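Swapping a bromophenyl for a methylphenyl on the shared core

The source may hold more compounds than are shown below. What is called first, only, known or untested is meant among the compounds shown, and "the series" means these compounds.

Compound 3 `C=CCn1c(=O)/c(=C\c2cccc(Br)c2)[nH]c(=O)/c1=C\c1ccccc1OC` gives 5400 nM in a functional assay on HeLa cells (Homo sapiens) for cytotoxicity, read by CCK-8 assay, with a stated time of 72 h; a higher number here means a weaker inhibitor, a lower number a stronger inhibitor. Among the three measured compounds it stands second highest: compound 1 `C=CCn1c(=O)/c(=C\c2cccc(Cl)c2Cl)[nH]c(=O)/c1=C\c1ccccc1OC` gives 1600 nM, and compound 2 `C=CCn1c(=O)/c(=C\c2cc(Br)ccc2F)[nH]c(=O)/c1=C\c1ccccc1OC` gives 34600 nM. The step of a 3.4-fold higher number from compound 1 to compound 3 (0.53 log units; beyond the scatter) and the step of a 6.4-fold lower number from compound 2 to compound 3 (0.81 log units; beyond the scatter) set compound 3 between the other two, while the step of a 22-fold higher number from compound 1 to compound 2 (1.33 log units; beyond the scatter) shows how far a change of the aryl group at this position can move the number.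

Compound 4 `C=CCn1c(=O)/c(=C\c2ccc(C)cc2)[nH]c(=O)/c1=C\c1ccccc1OC` differs from compound 3 in one place: 4-methylphenyl in place of 3-bromophenyl on a double-bonded chain carbon bound to an aromatic carbon. Within the data shown here, no measured step exchanges a bromine for a methyl on this ring, so the only steps that bear on it are those in which the aryl group itself was varied, and these ranged from modest to large and ran in both directions. On that basis a modest rise in the number is expected for compound 4, namely a 2.2-fold higher number from compound 3 to compound 4 (0.35 log units; beyond the scatter). Compound 4 is therefore estimated at 12000 nM in this assay, with a range from 4000 nM to 40000 nM.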

Compound 4, half-maximal inhibitory concentration: "not active" (no number reported)
Compound 4: no number reported; the estimate stays without a comparison.
By their numbers in this assay, from the lowest: compound 1; then compound 3; then compound 2.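

Among these compounds, compound 4 is reported as "not active" with no number in this assay, so no step from compound 3 to compound 4 can be read. No measured evidence bears on this result. The compounds shown leave open how far 4-methylphenyl in place of 3-bromophenyl moves the number.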